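A few compounds are considered here, and "the series" means these few. Any claim that something is new, unique, unknown or untested is made for them only; others in the source may bear on it.

Compound 2 `Cc1cc(C)c(CN2CCc3c(Cl)cc(-c4c(C)noc4C)c(Cl)c3C2=O)c(=O)[nH]1` gives 15.7 10^-6 cm/s in an ADME assay on MDCK cells (Canis lupus familiaris) for permeability, read by LC-MS, with a stated time of 90 min, tested at 2 uM (on this read-out higher numbers stand for higher permeability and lower numbers for lower permeability), the highest of the two numbers in hand. Compound 1 `Cc1cc(C)c(CN2CCc3c(Cl)cc([C@@H](CO)[C@@H]4CCOC4)c(Cl)c3C2=O)c(=O)[nH]1` gives 3 10^-6 cm/s, and compound 3 `Cc1cc(C)c(CN2CCc3c(Cl)cc(C(CO)C4CCOC4)c(Cl)c3C2=O)c(=O)[nH]1` gives 2.5 10^-6 cm/s; 2.7 10^-6 cm/s (2 entries); the agreement within the several entries of compound 3 in this assay, 2.5 10^-6 cm/s; 2.7 10^-6 cm/s (2 entries) shows how closely repeats sit, and compounds 1 and 3 differ only in the fact that one of compounds 1 and 3 is drawn with a defined configuration and the other without, at the place where they differ, their values lying within the scatter of each other. The change to compound 4 `Cc1cc(C)c(CN2CCc3c(Cl)cc([C@H](CO)[C@H]4CCCO4)c(Cl)c3C2=O)c(=O)[nH]1` is a group of 8 heavy atoms (6 carbon, 2 oxygen; one five-membered non-aromatic ring with 1 hetero atom) in place of a group of 7 heavy atoms (5 carbon, 1 nitrogen, 1 oxygen; one five-membered aromatic ring with 2 hetero atoms), on an aromatic carbon. It runs the measured step of a 5.2-fold higher number from compound 1 to compound 2 (0.72 log units; beyond the scatter) in reverse, so a fall of roughly that size is expected, a 5.2-fold lower number from compound 2 to compound 4 (0.72 log units; beyond the scatter). Compound 4 is therefore estimated at 3 10^-6 cm/s, with a likely range from 1.5 10^-6 cm/s to 6 10^-6 cm/s.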

Compound 4, apparent permeability: 4.1 10^-6 cm/s
Beside the measured number, compound 4's estimate is 1.4-fold (0.14 log units) below it, and the stated range covers the measured number.
By their numbers in this assay, from the lowest: compounds 1 and 4 (each within the scatter of the next); then compound 2.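

In this assay, a second non-aromatic group on this aromatic carbon also gives a lower number than 3,5-dimethyl-1,2-oxazol-4-yl (a 3.8-fold lower number from compound 2 to compound 4 (0.58 log units; beyond the scatter)), so the gap first seen with compound 1 is not tied to one such group. The two non-aromatic groups themselves are not separated (a 1.4-fold higher number from compound 1 to compound 4 (0.14 log units; within the scatter)). Nothing in hand gives a cause for the gap.

The step changes ring type and hydrogen-bond donor count together, so these stay unseparated. Open too, going by these compounds, is whether a methyl ether chain or an amine here would read nearer compound 2 or compound 4.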